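Removing one methyl from the amide-bearing aryl group

The compounds below may be only part of what the source reports. "The series", "measured", "known", "first", "only" and "open" are said of these compounds alone.

Three compounds share a core in which an indole-type azo unit is joined to a benzamide whose nitrogen carries an aromatic group. Compound 1 `Cc1cccc(NC(=O)c2ccc(/N=N\c3c[nH]c4ccccc34)cc2)c1C`, compound 2 `O=C(Nc1ccccc1F)c1ccc(/N=N\c2c[nH]c3ccccc23)cc1` and compound 3 `O=C(Nc1ccc([N+](=O)[O-])cc1)c1ccc(/N=N\c2c[nH]c3ccccc23)cc1` were tested in a functional assay on MCF7 cells (Homo sapiens) for inhibition, read by MTT assay, with a stated time of 72 h; on this read-out lower numbers stand for stronger inhibition and higher numbers for weaker inhibition. Compound 1 gives 106000 nM, compound 2 gives 83800 nM and compound 3 gives 54500 nM. The number for compound 1 is the largest of the three, yet the step of a 1.3-fold lower number from compound 1 to compound 2 (0.10 log units; within the scatter) and the step of a 1.9-fold lower number from compound 1 to compound 3 (0.29 log units; within the scatter) both stay within the scatter, as does a 1.5-fold lower number from compound 2 to compound 3 (0.19 log units; within the scatter).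

Compound 4 `Cc1cccc(NC(=O)c2ccc(/N=N\c3c[nH]c4ccccc34)cc2)c1` is not yet measured. It differs from compound 1 in one place: hydrogen in place of methyl on an aromatic carbon. Every measured step also changes only the aromatic group on the amide-type nitrogen, and none of them moved the number beyond the scatter, so the step of a 1.2-fold lower number from compound 1 to compound 4 (0.07 log units; within the scatter) is expected to be of the same kind. Compound 4 is therefore estimated at 90000 nM, with a range from 45000 nM to 180000 nM.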

Compound 4, half-maximal inhibitory concentration: 73400 nM
Compound 4: the middle estimate sits 1.2-fold (0.09 log units) above what was measured; low and high end bracket the measured number.
By their numbers in this assay, from the lowest: compounds 3, 4, 2 and 1 (each within the scatter of the next).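

Unlike the earlier steps, which swap the whole aromatic group on the amide-type nitrogen, this one removes only the methyl ortho to a large group, turning 2,3-dimethylphenyl into 3-methylphenyl; in this assay the result is a 1.4-fold lower number from compound 1 to compound 4 (0.16 log units; within the scatter), so methyl and hydrogen at this position cannot be told apart. The 3-methylphenyl group cannot be told apart from the other aromatic groups either, with a 1.3-fold higher number from compound 3 to compound 4 (0.13 log units; within the scatter) and a 1.1-fold lower number from compound 2 to compound 4 (0.06 log units; within the scatter), so a single methyl adds to the flat picture across these compounds. No measurement at hand offers an explanation for this result.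

On these data alone, whether an amine, a carboxylic acid or a longer chain on this same aromatic carbon would move the number beyond the scatter remains open. So does the outcome of removing the remaining methyl to leave a plain phenyl group.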